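Moving the acid out by a carbon on a carbon-only ring

The source may report more compounds than this note shows. Statements on the series, on what has been measured and on what is new or still open speak of the compounds shown alone.

Compound 2 `C[C@H](c1ccc(F)cc1)N(Cc1cccc(C(=O)O)n1)C(=O)c1cnc2ccccc2c1` is tested in an assay on CHO T-rex cells for antagonist activity at transient receptor potential cation channel subfamily M member 8 (Homo sapiens), read by calcium flux, with a stated time of 20 min (on this read-out lower numbers stand for stronger inhibition and higher numbers for weaker inhibition), where compound 2 gives 1160 nM. That is the higher of the two values recorded; compound 1 `C[C@H](c1ccc(F)cc1)N(Cc1cccc(C(=O)O)c1)C(=O)c1cc2ccccc2s1` gives 145 nM in this assay, and the gap between the two lies beyond the usual scatter. Within the data shown here, compound 1 differs from compound 2 in more than one place, so no single step between them is drawn.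

Compound 3 `C[C@H](c1ccc(F)cc1)N(Cc1cccc(CC(=O)O)c1)C(=O)c1cnc2ccccc2c1` has not yet been measured in this assay. It differs from compound 2 in one place: 3-(carboxymethyl)phenyl in place of 6-carboxypyridin-2-yl on a saturated chain carbon bound to an amide-type nitrogen. Because compound 1, whose ring at this position is also carbon only, gives 145 nM, compound 3 is expected to move toward stronger inhibition, though the acid now sits on a carboxymethyl group rather than directly on the ring, so the expected step from compound 2 to compound 3, a 2.3-fold lower number from compound 2 to compound 3 (0.37 log units; beyond the scatter), is modest. Compound 3 is estimated at 500 nM, with a range from 150 nM to 1700 nM.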

Compound 3, half-maximal inhibitory concentration: > 3240 nM
Compound 3 was reported as a limit; the forecaster's own chance of this, stated with the estimate: 5%; at least 6.4-fold (0.81 log units) between middle value and limit.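

Putting 3-(carboxymethyl)phenyl in place of 6-carboxypyridin-2-yl on the saturated chain carbon bound to an amide-type nitrogen weakens inhibition in this assay, with an at least 2.7-fold higher number from compound 2 to compound 3 (0.44 log units; beyond the scatter). Compound 3 stands at a limit of the assay, not at a number: the limit of > 3240 nM in this assay, at which 1 of the 3 values shown sits. Among these compounds, this is the first change at this position that can be read on its own, as the earlier pair differs in more than one place, and it shows that the inhibition of the core of compound 2 does not survive this exchange.

The exchange removes the ring nitrogen and also moves the acid onto a carboxymethyl group, and the compounds shown do not separate these two changes. Still open, from the compounds shown here alone, is how the core of compound 2 would read with a carboxylic acid directly on the carbon-only ring, or with a carboxymethyl group on the ring that keeps its nitrogen.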